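The compounds below may be only part of what the source reports. "The series", "measured", "known", "first", "only" and "open" are said of these compounds alone.

Compound 2 `Cc1c(C(=O)c2ccccc2)cc(C(=O)NCc2cccc(Cl)c2)n1Cc1ccccc1` stands at the edge of what a functional assay on MCF7 cells (Homo sapiens) for antiproliferative activity, read by MTT assay, with a stated time of 48 h (a lower number here means a stronger inhibitor, a higher number a weaker inhibitor), can read: compound 2 gives > 100000 nM, a limit rather than a number. Compound 1 `Cc1c(C(=O)c2ccccc2)cc(C(=O)NCc2cccc(I)c2)n1Cc1ccccc1` likewise gives > 100000 nM, also a limit. The step that the two limits leave unreadable from compound 1 to compound 2 is unreadable, since both values sit at the limit of > 100000 nM in this assay, at which 2 of the 2 values shown sit. Compound 3 `Cc1ccc(Cn2c(C(=O)NCc3cccc(Cl)c3)cc(C(=O)c3ccccc3)c2C)cc1` differs from compound 2 by methyl in place of hydrogen on an aromatic carbon. Among the measured compounds shown here, no measured step bears on this change, so nothing in the data moves the expectation away from the limit. The step of a number no higher from compound 2 to compound 3 (the limit leaves the size open) is expected to be small. Compound 3 is estimated at 100000 nM, between 30000 nM and 300000 nM.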

Compound 3, half-maximal inhibitory concentration: > 100000 nM
Compound 3: a limit, no number; the forecaster's own chance of this, stated with the estimate: 80%; the middle value lies on the limit itself.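

No step can be read from compound 2 to compound 3, since both values are limits and not numbers: the limit of > 100000 nM in this assay, at which 3 of the 3 values shown sit.

The compounds shown leave open what the methyl on the benzyl group does in this assay, and whether any change to the shared core gives a measurable value there.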